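Dichlorophenyl swap on the fused pentacyclic lactone

The source may report more compounds than this note shows. Statements on the series, on what has been measured and on what is new or still open speak of the compounds shown alone.

Measured compounds in a functional assay on B16-F10 cells (Mus musculus) for cytotoxicity; on this read-out lower numbers stand for stronger inhibition and higher numbers for weaker inhibition:
- compound 1 `O=c1cc(O)c2cc(F)ccc2o1`: 70700 nM
- compound 2 `O=c1oc2ccccc2c2nc3c(ccc4cc[nH]c43)c(-c3ccc(O)cc3)c12`: 70700 nM

Compound 1 is a small bicyclic fragment; compound 2 is a fused system of five rings carrying a 4-hydroxyphenyl group. In this assay compound 2 gives 70700 nM, level with compound 1 at the digits shown, so both sit at weak inhibition with no separation beyond the scatter. For the measured compounds named here, no step between them is counted, since they share no single point of difference.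

Compound 3 `O=c1oc2ccccc2c2nc3c(ccc4cc[nH]c43)c(-c3cccc(Cl)c3Cl)c12` keeps the core of compound 2 and differs only at the aromatic carbon opposite the ring nitrogen: 2,3-dichlorophenyl in place of 4-hydroxyphenyl on an aromatic carbon. The change removes the only hydrogen-bond donor and acceptor of the pendant ring and brings in two chlorines.

With only two measured points, both weak and indistinguishable, the series gives no direction for this change. The expectation for the step in this assay is therefore no change beyond the scatter, a 1.2-fold lower number from compound 2 to compound 3 (0.07 log units; within the scatter). Compound 3 is estimated at 60000 nM, with a range from 15000 nM to 150000 nM, and a real chance that only a limit is reported.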

Compound 3, half-maximal inhibitory concentration: 70700 nM
For compound 3 the middle estimate is 1.2-fold (0.07 log units) below the measured one, within the range that was stated.
By their numbers in this assay, from the lowest: compounds 1, 2 and 3 (each within the scatter of the next).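

In this assay, for the compounds shown here, 2,3-dichlorophenyl in place of 4-hydroxyphenyl on the aromatic carbon opposite the ring nitrogen gives no change at the digits printed from compound 2 to compound 3 (within the scatter) and provides the first readable step at this position. The hydrogen-bond donor and acceptor of 4-hydroxyphenyl are absent from 2,3-dichlorophenyl, which brings in two chlorines, yet this read-out does not separate the two groups on the shared core, so neither group can be preferred at this position on these data. No supporting measurement is available to account for this result.

Still open, on these data alone, is whether any group at this aromatic carbon can move the number away from this level, for example a phenyl ring carrying an amine or a carboxylic acid, or a longer alkyl chain in place of the aromatic ring. Also open, as far as these compounds go, is whether a single chlorine on the phenyl ring would read the same as 2,3-dichlorophenyl, and whether changes elsewhere on the shared core would shift the value where this one does not.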